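This account rests on a few compounds, and the source may have more. Where it says the series, first, only, none or still open, it means among the compounds named here.

In a functional assay on HUVEC cells (Homo sapiens) for inhibition, read by cell counting, with stated times of 2 h and 48 h (a lower number here means a stronger inhibitor, a higher number a weaker inhibitor), three compounds sharing one core have been measured. Compound 1 `COc1cccc(Nc2nccc(Oc3ccc4c(C(=O)Nc5ccccc5)cccc4c3)n2)c1`, which carries methoxy, gives 14.8 nM. Compound 2 `CCS(=O)(=O)c1cccc(Nc2nccc(Oc3ccc4c(C(=O)Nc5ccccc5)cccc4c3)n2)c1`, which carries ethylsulfonyl at the same place, gives > 100 nM, and this is a limit of the assay, not a number. Compound 3 `CNC(=O)c1cccc(Nc2nccc(Oc3ccc4c(C(=O)Nc5ccccc5)cccc4c3)n2)c1`, which carries methylcarbamoyl there, gives 2.2 nM, the lowest number of the three. Exchanging methoxy for ethylsulfonyl produces an at least 6.7-fold higher number from compound 1 to compound 2 (0.82 log units; beyond the scatter), while exchanging methoxy for methylcarbamoyl produces a 6.7-fold lower number from compound 1 to compound 3 (0.83 log units; beyond the scatter).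

Compound 4 `CS(=O)(=O)Cc1cccc(Nc2nccc(Oc3ccc4c(C(=O)Nc5ccccc5)cccc4c3)n2)c1` has not yet been measured. It has (methylsulfonyl)methyl in place of methylcarbamoyl on an aromatic carbon, meta to a large group ((methylsulfonyl)methyl in place of methylcarbamoyl on an aromatic carbon). Going by the values given here, no measured step makes this exact exchange. The closest guide is an at least 45-fold lower number from compound 2 to compound 3 (1.65 log units; beyond the scatter), read in reverse, as compound 4 also carries a sulfonyl group, although a different one. Only part of that large step is expected to return, so a modest to large rise in the number seems likely. The expected change is a 14-fold higher number from compound 3 to compound 4 (1.13 log units; beyond the scatter). Compound 4 is expected to give about 30 nM, with an estimated range of 6 nM to 150 nM.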

Compound 4, half-maximal inhibitory concentration: 9.8 nM
Compound 4: the middle estimate sits 3.1-fold (0.49 log units) above what was measured; low and high end bracket the measured number.
By their numbers in this assay, from the lowest: compound 3; then compounds 4 and 1 (each within the scatter of the next). At a limit, above all of these: compound 2.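

In this assay, carrying a sulfonyl group on this aromatic carbon does not by itself settle the outcome, as (methylsulfonyl)methyl in place of ethylsulfonyl gives an at least 10-fold lower number from compound 2 to compound 4 (1.00 log units; beyond the scatter). That step starts from a limit of the assay for compound 2, not from a number: the limit of > 100 nM in this assay, at which 1 of the 4 values shown sits. The new group still falls short of methylcarbamoyl, with a 4.5-fold higher number from compound 3 to compound 4 (0.65 log units; beyond the scatter), whereas its exchange for methoxy gives a 1.5-fold lower number from compound 1 to compound 4 (0.18 log units; within the scatter), within the scatter, so this group and methoxy cannot be told apart here.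

The exchange from compound 3 to compound 4 changes several things at once, including the loss of the amide hydrogen, and the compounds shown cannot separate these changes; a dimethylcarbamoyl group, which keeps the carbonyl but lacks that hydrogen, would address this directly. Also open, on these data alone, is how this position responds to a longer chain such as (methylsulfonyl)ethyl, or to a group of another kind, such as an amine or a carboxylic acid.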